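Notes on the step from compound 3 to compound 4

This account rests on a few compounds, and the source may have more. Where it says the series, first, only, none or still open, it means among the compounds named here.

In a functional assay on HepG2 cells (Homo sapiens) for inhibition, read by MTT assay, with a stated time of 48 h (on this read-out higher numbers stand for weaker inhibition and lower numbers for stronger inhibition), compound 1 `COc1ccc(-n2c(SCc3ccccc3)nnc2-c2cc(OC)c(OC)c(OC)c2)cc1` reads > 60000 nM, which is a limit of the assay and not a number. Going by the values given here, compound 2 `COc1ccc(CSc2nnc(-c3cc(OC)c(OC)c(OC)c3)n2-c2ccc(OC)cc2)cc1` gives 41100 nM, and compound 3 `COc1ccc(-n2c(SCC(=O)c3ccc(F)cc3)nnc2-c2cc(OC)c(OC)c(OC)c2)cc1` gives 10700 nM, the lowest number so far. Compound 3 stands clear of its neighbours, with a 3.8-fold lower number from compound 2 to compound 3 (0.58 log units; beyond the scatter) and an at least 5.6-fold lower number from compound 1 to compound 3 (0.74 log units; beyond the scatter). The methoxy step, an at least 1.4-fold lower number from compound 1 to compound 2 (0.16 log units; that floor lies within the scatter), rests on a limit and concerns a different change.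

Compound 4 `COc1ccc(-n2c(SCC(=O)c3ccc4ccccc4c3)nnc2-c2cc(OC)c(OC)c(OC)c2)cc1` has naphthalen-2-yl in place of 4-fluorophenyl on the carbonyl carbon (naphthalen-2-yl in place of 4-fluorophenyl on a carbonyl carbon). Among the compounds with values here, no measured step compares two groups at that place. The closest evidence is the pair of steps that introduced (4-fluorophenyl)carbonyl, which shows that this assay responds to changes in the group on the sulfur-bound chain carbon, but neither step gives a direction for this exchange. No shift beyond the scatter is therefore expected, and the expected step is a 1.3-fold lower number from compound 3 to compound 4 (0.13 log units; within the scatter). For compound 4 the estimated value is 8000 nM, with an expected range of 2500 nM to 26000 nM.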

Compound 4, half-maximal inhibitory concentration: > 60000 nM
Compound 4 ended at the assay's limit; the forecaster's own chance of this, stated with the estimate: 10%; at least 7.5-fold (0.87 log units) between middle value and limit.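

Going by these compounds alone, with naphthalen-2-yl in place of 4-fluorophenyl on the carbonyl carbon, this assay gives an at least 5.6-fold higher number from compound 3 to compound 4 (0.74 log units; beyond the scatter), so the group at this place decides the read-out, which no earlier pair could show. The carbonyl alone does not secure a lower number: the exchange of 4-methoxyphenyl for (naphthalen-2-yl)carbonyl on the saturated chain carbon gives an at least 1.4-fold higher number from compound 2 to compound 4 (0.16 log units; that floor lies within the scatter), a floor that does not establish a change in either direction. The step between compound 1 and compound 4 cannot be read, and the reading of compound 4 is a limit and not a number: the limit of > 60000 nM in this assay, at which 2 of the 4 values shown sit.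

The compounds shown do not separate the loss of the fluorine from the gain of a second aromatic ring. As far as these compounds go, whether an amine or a carboxylic acid on the aryl group would hold the number of compound 3 also stays open.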